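Working notes: cytotoxicity series and the step to compound 4

The source may report more compounds than this note shows. Statements on the series, on what has been measured and on what is new or still open speak of the compounds shown alone.

Within the data shown here, compound 1 `O=C(COc1cccc2ccccc12)N/N=C/c1ccc(O)cc1` is measured in an ADME assay on MT4 cells (Homo sapiens) for cytotoxicity, read by MTT assay, with a stated time of 4 days (a higher number here means that more compound is tolerated, a lower number that less compound is tolerated), at 26.5 ug/mL, the second highest of the three numbers known so far. Compound 3 `COc1ccc(/C=N/NC(=O)COc2cccc3ccccc23)cc1OC` gives 14.7 ug/mL in this assay, a gap to compound 1 that is within the scatter. Among the measured compounds shown here, compound 2 `O=C(COc1cccc2ccccc12)N/N=C/c1ccc([N+](=O)[O-])cc1` gives 87.9 ug/mL, and the step of a 3.3-fold higher number from compound 1 to compound 2 (0.52 log units; beyond the scatter) is the only recorded one that changes a single place. Compound 4 `O=C(COc1cccc2ccccc12)N/N=C/c1ccccc1Cl` differs from compound 1 by 2-chlorophenyl in place of 4-hydroxyphenyl on a carbon with a double bond to nitrogen. For the measured compounds named here, because a 3.3-fold higher number from compound 1 to compound 2 (0.52 log units; beyond the scatter) also takes the hydroxy away and is modest, a modest rise for compound 4, or none beyond the scatter, is expected; no measured step brings in a chlorine. The estimate for compound 4 in this assay is 40 ug/mL, with a range from 15 ug/mL to 110 ug/mL. This corresponds to an expected step of a 1.5-fold higher number from compound 1 to compound 4 (0.18 log units; within the scatter).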

Compound 4, half-maximal cytotoxic concentration: 56.2 ug/mL
Compound 4: the middle estimate sits 1.4-fold (0.15 log units) below what was measured; low and high end bracket the measured number.
By their numbers in this assay, from the lowest: compounds 3 and 1 (each within the scatter of the next); then compounds 4 and 2 (each within the scatter of the next).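

In this assay the replacement of 4-hydroxyphenyl by 2-chlorophenyl gives a 2.1-fold higher number from compound 1 to compound 4 (0.33 log units; beyond the scatter) at this place, a second change beyond the scatter alongside a 3.3-fold higher number from compound 1 to compound 2 (0.52 log units; beyond the scatter) in the same direction. Both replacements remove the hydroxy, but the step with chlorine cannot separate that loss from the entry of the chlorine. Nothing measured here accounts for the rise.

As far as these compounds go, whether a phenyl group carrying an amine or a carboxylic acid on this carbon would follow the same direction remains open.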